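A few compounds are considered here, and "the series" means these few. Any claim that something is new, unique, unknown or untested is made for them only; others in the source may bear on it.

In an ADME assay on microsomes from liver (Rattus norvegicus) for metabolic stability, read by LC-MS, in the presence of a further agent that is not named here (on this read-out higher numbers stand for fast clearance and lower numbers for slow clearance), compound 1 `Cc1ncc(C)n2nc(-c3ccn4cc(-c5ccc(Br)cc5)nc4n3)nc12` gives 15 mL.min-1.g-1. This number lies within the usual scatter of both other measured compounds: compound 2 `Cc1ncc(C)n2nc(-c3ccc4nc(-c5ccccn5)[nH]c4c3)nc12` gives 11.1 mL.min-1.g-1 and compound 3 `Cc1ncc(C)n2nc(-c3ccc4nc(-c5ccccc5)[nH]c4c3)nc12` gives 27.4 mL.min-1.g-1. Compound 4 `COc1ccccc1-c1cn2ccc(-c3nc4c(C)ncc(C)n4n3)nc2n1` keeps the core of compound 1 but carries 2-methoxyphenyl in place of 4-bromophenyl on an aromatic carbon. Going by the values given here, no measured step makes this swap. The only one available, a 2.5-fold higher number from compound 2 to compound 3 (0.39 log units; beyond the scatter), is modest and involves a different group on a different core, so it offers only a rough guide to size and none to direction. A step beyond the scatter is therefore not expected in this assay. The estimated change is a 1.3-fold higher number from compound 1 to compound 4 (0.10 log units; within the scatter). For compound 4 the expected value is 19 mL.min-1.g-1, with an estimated range from 8 mL.min-1.g-1 to 45 mL.min-1.g-1.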

Compound 4, intrinsic clearance in microsomes: 9.1 mL.min-1.g-1
For compound 4 the middle estimate is 2.1-fold (0.32 log units) above the measured one; low and high end bracket the measured number.
By their numbers in this assay, from the lowest: compounds 4, 2, 1 and 3 (each within the scatter of the next, the first and the last beyond it).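

Going by these compounds alone, on this aromatic carbon of the five-membered ring, the first measured swap on the core of compound 1 gives a 1.6-fold lower number from compound 1 to compound 4 (0.22 log units; within the scatter) in this assay. So an ring carrying a methoxy group in the 2-methoxyphenyl arrangement and one carrying bromine in the 4-bromophenyl arrangement read alike here, within the usual scatter. Nothing measured here accounts for this result. From the compounds shown here alone, whether a group other than a substituted phenyl, such as an amine or a carboxylic acid, would shift clearance beyond the scatter at this place stays open. Also open, going by these compounds, is whether pyridin-2-yl here would behave as it does on the core of compound 2.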